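Third aziridine in place of the carbamate-bearing chain

The compounds below may be only part of what the source reports. "The series", "measured", "known", "first", "only" and "open" are said of these compounds alone.

Measured compounds:
Compound 1 `CC1=C(N2CC2)C(=O)C(CC(C)OC(N)=O)=C(N2CC2)C1=O`: 5.79
Compound 2 `CCC(COC(N)=O)C1=C(N2CC2)C(=O)C(C)=C(N2CC2)C1=O`: 5.66
Compound 3 `CCCC1=C(N2CC2)C(=O)C(CCOC(N)=O)=C(N2CC2)C1=O`: 5.23

Three compounds on a shared quinone core carrying two aziridin-1-yl groups have been tested in a functional assay on L1210 cells (Mus musculus), with a stated time of 12 days; on this read-out higher numbers stand for higher potency (the scale is a negative logarithm) and lower numbers for lower potency. Compound 1 gives the highest of the three numbers, 5.79. Compound 2, at 5.66, lies within the scatter of compound 1, so the two cannot be ordered. Compound 3, at 5.23, sits beyond the scatter below compound 1. No pair among these three differs in only one place, so no single step can be read off.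

Compound 4 `CC1=C(N2CC2)C(=O)C(N2CC2)=C(N2CC2)C1=O` is not yet measured. It differs from compound 1 in one place: a group of 3 heavy atoms (2 carbon, 1 nitrogen; one three-membered non-aromatic ring with 1 hetero atom) in place of a group of 7 heavy atoms (4 carbon, 1 nitrogen, 2 oxygen; no ring), on a double-bonded ring carbon. The core of compound 1 thereby carries three aziridin-1-yl groups and a methyl group, with no open chain left.

Among the measured compounds shown here, no measured pair shows what such a change does. The account expects an upward step from compound 1 to compound 4 of a number 0.81 log units higher from compound 1 to compound 4 (beyond the scatter), beyond the scatter. The estimate for compound 4 in this assay is 6.6, within a range from 5.6 to 7.6.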

Compound 4, logarithm of the reciprocal of the active concentration, log(1/C): 6.21
Estimate against measurement, compound 4: 0.39 log units above, within the range that was stated.
By their numbers in this assay, from the lowest: compound 3; then compounds 2 and 1 (each within the scatter of the next); then compound 4.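

On this double-bonded ring carbon, the open chain of 7 heavy atoms can give way to an aziridin-1-yl group without loss in this assay: the swap gives a number 0.42 log units higher from compound 1 to compound 4 (beyond the scatter). The chain, with its hydrogen-bond donor, is therefore not needed at this position for a value at this level, and a core with three aziridin-1-yl groups and a methyl group reads higher than compound 1. Nothing available here accounts for the step.

The single change removes the chain and adds the aziridin-1-yl group together, so the compounds shown leave open which of the two carries the step. Going by these compounds, an amine or a shorter chain at this position would help separate the two, and whether the step holds on cores with other neighbouring groups also stays open.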